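Chloro for methoxy on the side chain

A few compounds are considered here, and "the series" means these few. Any claim that something is new, unique, unknown or untested is made for them only; others in the source may bear on it.

Compound 1 `CC/C(=C(/c1ccc(/C=C/C(=O)O)cc1)c1ccc2[nH]ncc2c1)c1ccccc1`: 7.2 nM
Compound 2 `COC/C(=C(/c1ccc(/C=C/C(=O)O)cc1)c1ccc2[nH]ncc2c1)c1ccccc1`: 88 nM
Compound 3 `COCC/C(=C(/c1ccc(/C=C/C(=O)O)cc1)c1ccc2[nH]ncc2c1)c1ccccc1`: 63 nM

In a functional assay on MCF7 cells (Homo sapiens) for cytotoxicity, read by CellTiter-Glo, with a stated time of 5 days (on this read-out lower numbers stand for stronger inhibition and higher numbers for weaker inhibition), compound 3 gives 63 nM, the second highest of the three numbers. Its nearest neighbour is compound 2, and the difference a 1.4-fold lower number from compound 2 to compound 3 (0.15 log units; within the scatter) lies within the scatter. Its furthest is compound 1, with a step of an 8.8-fold higher number from compound 1 to compound 3 (0.94 log units; beyond the scatter) that lies beyond it.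

Compound 4 `O=C(O)/C=C/c1ccc(/C(=C(/CCCl)c2ccccc2)c2ccc3[nH]ncc3c2)cc1` differs from compound 3 in one place: chloro in place of methoxy on a saturated chain carbon, two bonds along the chain from a double-bonded chain carbon. For the measured compounds named here, no measured pair shows chloro in place of methoxy, so the expectation rests on what the methoxy itself did. The step of an 8.8-fold higher number from compound 1 to compound 3 (0.94 log units; beyond the scatter) shows that placing methoxy on that chain carbon gave a modest rise in the number, and the step of a 12-fold higher number from compound 1 to compound 2 (1.09 log units; beyond the scatter) shows a large rise when methoxy sat one carbon closer to the double bond. Removing the methoxy in favour of chloro is therefore expected to give a lower number for compound 4 in this assay, though by an uncertain amount, estimated as a 3.2-fold lower number from compound 3 to compound 4 (0.50 log units; beyond the scatter). Compound 4 is thus expected at about 20 nM, within a range of 6 nM to 70 nM.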

Compound 4, half-maximal inhibitory concentration: 9 nM
The estimate for compound 4 lay 2.2-fold (0.35 log units) above the measured number, within the range that was stated.
By their numbers in this assay, from the lowest: compounds 1 and 4 (each within the scatter of the next); then compounds 3 and 2 (each within the scatter of the next).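

In this assay, the 2-chloroethyl chain of compound 4 separates clearly from the 2-methoxyethyl chain (a 7.0-fold lower number from compound 3 to compound 4 (0.85 log units; beyond the scatter)), so the rise that came with methoxy on this chain carbon does not extend to every replacement of hydrogen there. Chloro in place of hydrogen at this position leaves no difference that can be told from the scatter (a 1.3-fold higher number from compound 1 to compound 4 (0.10 log units; within the scatter)), so this position accepts chloro without a measurable cost. The same separation appears against methoxy on a saturated chain carbon bound to a double-bonded chain carbon (a 9.8-fold lower number from compound 2 to compound 4 (0.99 log units; beyond the scatter)), so both methoxy compounds stand apart from compound 4.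

As far as these compounds go, whether a 2-fluoroethyl chain, a 2-hydroxyethyl chain or a longer chain would fall with compound 4 or with compound 3 remains open. The data at hand offer no measurement that explains the gap between chloro and methoxy at this position.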